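A few compounds are considered here, and "the series" means these few. Any claim that something is new, unique, unknown or untested is made for them only; others in the source may bear on it.

Measured so far:
compound 1, `COc1ccc(CNc2nc(SC)nc3ccccc23)cc1`: > 100000 nM
compound 2, `CCCCC[Se]c1nc(NCc2ccccc2)c2ccccc2n1`: 99400 nM
compound 3, `CCCCC[Se]c1nc(NCc2ccc(SC)cc2)c2ccccc2n1`: 95300 nM

In a functional assay on MCF7 cells (Homo sapiens) for cytotoxicity, read by MTT assay, with a stated time of 72 h (on this read-out higher numbers stand for lower toxicity in this test and lower numbers for higher toxicity in this test), compound 3 gives 95300 nM, the lowest of the two numbers obtained, with compound 2 close by at 99400 nM. Compound 1 sits at the limit of > 100000 nM in this assay, at which 1 of the 3 values shown sits, a limit of the assay and not a number. Among the measured compounds shown here, the single measured step, a 1.0-fold lower number from compound 2 to compound 3 (0.02 log units; within the scatter), concerns the methylsulfanyl on the benzyl ring and stays within the scatter.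

Compound 4, `CSc1ccc(CNc2nc(SC)nc3ccccc23)cc1`, differs from compound 3 at another place: a group of 2 heavy atoms (1 carbon, 1 sulfur; no ring) in place of a group of 6 heavy atoms (5 carbon, 1 selenium; no ring), on an aromatic carbon. For the measured compounds named here, no measured step covers this change on the core; the step of a 1.0-fold lower number from compound 2 to compound 3 (0.02 log units; within the scatter) does not bear on it. What is known is that compound 1, which also bears methylsulfanyl between two ring nitrogen atoms, reaches only the limit. Compound 4 is therefore expected to sit at or around the limit as well, and its number in this assay is estimated at 110000 nM, within 60000 nM to 250000 nM. That estimate means an expected step of a 1.2-fold higher number from compound 3 to compound 4 (0.06 log units; within the scatter), with a fair chance that only a limit is reported.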

Compound 4, concentration lethal to 50% of the cells: > 100000 nM
Compound 4 was reported as a limit (the forecaster's own chance of this, stated with the estimate: 60%); the middle value lies beyond the limit too.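

Compound 4 is a limit of the assay and not a number in this assay, and the same holds for compound 1: the limit of > 100000 nM in this assay, at which 2 of the 4 values shown sit. On these data alone, the readable step, an at least 1.0-fold higher number from compound 3 to compound 4 (0.02 log units; that floor lies within the scatter), is only a floor, so exchanging the selenium-bearing group of 6 heavy atoms for methylsulfanyl between two ring nitrogen atoms brings no measurable rise in toxicity in this test, while its full size stays unknown. With methylsulfanyl at this position, the methylsulfanyl on the benzyl ring does not bring a number below the limit any more than methoxy does, and the step between compound 1 and compound 4 cannot be read, as both are limits.

As far as these compounds go, how far compound 4 lies beyond the limit remains open. So does the effect of an amine, a carboxylic acid or a longer chain at this position.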